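Swapping a Piperazine Amide for an Anilide

The compounds below may be only part of what the source reports. "The series", "measured", "known", "first", "only" and "open" are said of these compounds alone.

Compound 1 `CN1CCN(C(=O)c2c(N)sc(-c3ccc(Cl)cc3)c2-c2ccc(Cl)cc2)CC1`: 590 nM
Compound 2 `Nc1sc(-c2ccc(Cl)cc2)c(-c2ccc(Cl)cc2)c1C(=O)NC1CC1`: 1950 nM
Compound 3 `CC1CN(C(=O)c2c(N)sc(-c3ccc(Cl)cc3)c2-c2ccc(Cl)cc2)CCN1`: 4930 nM

In a functional assay on A549 cells (Homo sapiens) for inhibition, read by sulforhodamine B assay, with a stated time of 72 h (on this read-out higher numbers stand for weaker inhibition and lower numbers for stronger inhibition), compound 3 stands highest of the three: an 8.4-fold higher number from compound 1 to compound 3 (0.92 log units; beyond the scatter) and a 2.5-fold higher number from compound 2 to compound 3 (0.40 log units; beyond the scatter). Compound 4 `Nc1sc(-c2ccc(Cl)cc2)c(-c2ccc(Cl)cc2)c1C(=O)Nc1ccccc1` keeps the shared core and changes only the amide partner: anilino in place of 3-methylpiperazin-1-yl on a carbonyl carbon. The measured step that bears most on this change is a 2.5-fold higher number from compound 2 to compound 3 (0.40 log units; beyond the scatter): compound 2, like compound 4, carries an amino group rather than a piperazin-1-yl on the carbonyl carbon, and that step ran upward, so moving back to such a group is expected to run modestly downward. For the measured compounds named here, compound 1 shows that another amide partner can sit far lower, but no measured step connects it to an anilino. For compound 4 the expected step is a 2.0-fold lower number from compound 3 to compound 4 (0.29 log units; within the scatter). Compound 4 is therefore estimated at 2500 nM, with a range from 800 nM to 8000 nM.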

Compound 4, half-maximal inhibitory concentration: 25000 nM
Compound 4: middle estimate off by 10-fold (1.00 log units), on the low side; measured number above the stated range.
By their numbers in this assay, from the lowest: compound 1; then compound 2; then compound 3; then compound 4.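

In this assay, an amino-type amide partner does not by itself keep the number low. The phenyl group on the amide-type nitrogen gives a much higher number than cyclopropyl (a 13-fold higher number from compound 2 to compound 4 (1.11 log units; beyond the scatter)). Anilino also sits above both piperazine partners (a 5.1-fold higher number from compound 3 to compound 4 (0.71 log units; beyond the scatter); a 42-fold higher number from compound 1 to compound 4 (1.63 log units; beyond the scatter)), and compound 4 has the highest number of the four, so the partner on the carbonyl carbon strongly shapes the result.

The compounds shown leave open whether a benzyl group or a longer alkyl chain on that nitrogen would fall nearer cyclopropyl or nearer phenyl. No available measurement explains these rises.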